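Chloro in Place of Hydrogen on a Weak Inhibitor

This account rests on a few compounds, and the source may have more. Where it says the series, first, only, none or still open, it means among the compounds named here.

Compound 1 `Nc1nc2cc(Cl)c(Cl)cc2n1Cc1ccccc1` gives 170000 nM in a functional assay on KB cells (Homo sapiens) for inhibition; a lower number here means a stronger inhibitor, a higher number a weaker inhibitor.
Compound 2 `Nc1nc2cc(Cl)c(Cl)cc2n1Cc1cccc(Cl)c1` gives 65000 nM in this assay.
For compound 3 `Clc1cc2nc(Br)n(Cc3ccccc3)c2cc1Cl` this assay reports only a limit, > 100000 nM.

Compound 2 differs from compound 1 by chloro in place of hydrogen on an aromatic carbon, and this change brought a 2.6-fold lower number from compound 1 to compound 2 (0.42 log units; beyond the scatter). The two cores differ by bromo in place of amino on an aromatic carbon; the step that the limit leaves unreadable from compound 1 to compound 3 has no readable size, since the value of compound 3 sits at the limit of > 100000 nM in this assay, at which 1 of the 3 values shown sits.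

Compound 4 `Clc1ccc(Cn2c(Br)nc3cc(Cl)c(Cl)cc32)cc1` has not yet been measured. It differs from compound 3 by chloro in place of hydrogen on an aromatic carbon. This is the same kind of change as from compound 1 to compound 2, though the place is not the same: meta to a large group in compound 2, para to a large group in compound 4.

In this assay compound 4 is expected to show a step that the limit leaves unreadable from compound 3 to compound 4, an expectation that rests on the step of a 2.6-fold lower number from compound 1 to compound 2 (0.42 log units; beyond the scatter) for the same kind of change, while the limit for compound 3 leaves the starting point uncertain. The estimate for compound 4 is 120000 nM, between 40000 nM and 400000 nM, with a fair chance that only a limit is reported again.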

Compound 4, half-maximal inhibitory concentration: > 100000 nM
Compound 4 ended at the assay's limit (the forecaster's own chance of this, stated with the estimate: 55%); the middle value is on the limit's open side.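

Compound 3 and compound 4 both sit at a limit of this assay rather than at a number, so no step between them can be read: the limit of > 100000 nM in this assay, at which 2 of the 4 values shown sit.

The compounds shown leave open whether chloro in place of hydrogen changes inhibition at all on the core of compound 3, as it did going from compound 1 to compound 2.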